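Chloro for Fluoro: Expected Clearance of Compound 4

A few compounds are considered here, and "the series" means these few. Any claim that something is new, unique, unknown or untested is made for them only; others in the source may bear on it.

Measured so far in an in vitro ADME assay on the whole organism (microsomes, liver, Mus musculus) for metabolic stability, read by LC-MS, with a stated time of 24 h, at a dose of 5 mg/kg by the intravenous route; a higher number here means faster removal of the compound, a lower number slower removal:
Compound 1, `CCCN(Cc1ccc(OC(F)(F)F)cc1)[C@@H]1COc2nc([N+](=O)[O-])cn2C1`, gives 407 mL.min-1.g-1.
Compound 2, `O=[N+]([O-])c1cn2c(n1)OC[C@@H](NCc1ccc(OC(F)(F)F)c(F)c1)C2`, gives 58.7 mL.min-1.g-1.
Compound 3, `O=[N+]([O-])c1cn2c(n1)OC[C@@H](NCc1ccc(OC(F)(F)F)cc1F)C2`, gives 95.6 mL.min-1.g-1.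

Among these three numbers, compound 3 holds the second highest. Its value and that of compound 2 lie within the usual scatter of repeated measurements, so the two cannot be told apart. Compound 1 sits clearly higher, beyond the scatter, which means faster removal.

Compound 4, `O=[N+]([O-])c1cn2c(n1)OC[C@@H](NCc1ccc(OC(F)(F)F)cc1Cl)C2`, has not yet been measured. It differs from compound 3 by chloro in place of fluoro on an aromatic carbon. Among the measured compounds shown here, no measured pair in this set shows the same exchange, so the size of the step is not known from these data. Putting chloro in place of fluoro is expected to leave the number roughly where it stands, and the step of a 1.2-fold higher number from compound 3 to compound 4 (0.06 log units; within the scatter) is expected to fall within the scatter. Compound 4 is therefore estimated at 110 mL.min-1.g-1, with a range from 55 mL.min-1.g-1 to 220 mL.min-1.g-1.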

Compound 4, intrinsic clearance in microsomes in the liver assay: 69.7 mL.min-1.g-1
Beside the measured number, compound 4's estimate is 1.6-fold (0.20 log units) above it; low and high end bracket the measured number.
By their numbers in the liver assay, from the lowest: compounds 2, 4 and 3 (each within the scatter of the next); then compound 1.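

Among the compounds shown here, this is the only measured exchange at this place, ortho to a large group, and in the liver assay it gives a 1.4-fold lower number from compound 3 to compound 4 (0.14 log units; within the scatter), so chloro and fluoro cannot be told apart there. In a physicochemical assay for solubility, at pH 6.8 (a higher number here means a more soluble compound, a lower number a less soluble compound), compound 3 gives 72 ug/mL and compound 4 gives 30 ug/mL, a gap beyond the scatter. The exchange therefore separates the two compounds in the physicochemical assay but not in the liver assay.

The compounds shown leave open what a methyl or a nitrile at this place would give in either the liver assay or the physicochemical assay.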